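Working notes: a methyl step carried across two cores

This account rests on a few compounds, and the source may have more. Where it says the series, first, only, none or still open, it means among the compounds named here.

Measured so far in an ADME assay on MT4 cells (Homo sapiens) for cytotoxicity, read by MTT assay, with a stated time of 96 h; a higher number here means that more compound is tolerated, a lower number that less compound is tolerated:
- compound 1, `O=C(Oc1ccc2ccc(=O)oc2c1CN1CCc2ccccc2C1)c1ccccc1`: > 100000 nM, a limit of the assay, not a number.
- compound 2, `Cc1cc(=O)oc2c(CN3CCc4ccccc4C3)c(OC(=O)c3ccccc3)ccc12`: > 100000 nM, likewise a limit of the assay.
- compound 3, `Cc1[nH]c2ccccc2c1Cc1c(OC(=O)CCCC(=O)O)ccc2ccc(=O)oc12`: 27000 nM.

Compound 4, `Cc1[nH]c2ccccc2c1Cc1c(OC(=O)CCCC(=O)O)ccc2c(C)cc(=O)oc12`, is not yet measured in this assay.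

The change from compound 1 to compound 2 is methyl in place of hydrogen on an aromatic carbon. Both values sit at the limit, so the step that the two limits leave unreadable from compound 1 to compound 2 cannot be read in size; this rests on (the limit of > 100000 nM in this assay, at which 2 of the 3 values shown sit). The change from compound 3 to compound 4 is methyl in place of hydrogen on an aromatic carbon, the same change as from compound 1 to compound 2, since the two place descriptions agree word for word. The difference between the core of compound 1 and the core of compound 3 is not broken down here.

Compound 3 is the only one of the three with a numeric value in this assay; the other two give limits. Among the measured compounds shown here, for compound 4 the step of no change at the digits printed from compound 3 to compound 4 (within the scatter) is expected to be small, because the only measured instance of this change, a step that the two limits leave unreadable from compound 1 to compound 2, gives no sign of a shift that the limits could show, and a methyl entering in place of hydrogen is a small change. Compound 4 is therefore estimated at 27000 nM, with a range from 10000 nM to 70000 nM, in which the value of compound 3, 27000 nM, is the anchor.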

Compound 4, half-maximal cytotoxic concentration: 29000 nM
Beside the measured number, compound 4's estimate is 1.1-fold (0.03 log units) below it; the measured number falls inside the stated range.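

In this assay, methyl in place of hydrogen on an aromatic carbon gives a 1.1-fold higher number from compound 3 to compound 4 (0.03 log units; within the scatter), so on the core of compound 3 the two values lie within the scatter of each other and this single pair shows no readable effect of the methyl. The same change on the core of compound 1 cannot be read in size, since both members of that pair give a limit of the assay rather than a number: the limit of > 100000 nM in this assay, at which 2 of the 4 values shown sit. The series therefore offers one readable instance of this change, not a comparison between two, and although nothing shown contradicts carrying the change from one core to the other, the data do not show that its size is the same on both cores.

The compounds shown leave open whether the picture holds for a group other than methyl at the same place, opposite the ring oxygen, such as ethyl, methoxy or trifluoromethyl. Among the compounds shown here, they also leave open how the differences between the core of compound 1 and the core of compound 3 divide among their separate parts, as no compound here changes those parts one at a time.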